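The source may report more compounds than this note shows. Statements on the series, on what has been measured and on what is new or still open speak of the compounds shown alone.

Of the compounds shown here, three sharing one core have been tested in a functional assay on A549 cells (Homo sapiens) for inhibition, read by MTT assay, with a stated time of 72 h; a higher number here means a weaker inhibitor, a lower number a stronger inhibitor. Compound 1 `CO[C@@H]1[C@H]2OC(=O)C[C@H]2O[C@@H]1[C@@H](O)c1ccccc1` gives 38300 nM, compound 2 `O=C1C[C@H]2O[C@H]([C@H](O)c3ccccc3)[C@H](O)[C@H]2O1` gives 35200 nM, and compound 3 `CO[C@@H]1[C@H]2OC(=O)C[C@H]2O[C@@H]1[C@H](O)c1ccccc1` gives 23600 nM. Compound 2 thus stands second highest of the three numbers, and every gap among these compounds lies within the scatter. Compound 4 `CO[C@H](c1ccccc1)[C@H]1O[C@@H]2CC(=O)O[C@@H]2[C@H]1O` arises from compound 2 by methyl in place of hydrogen on an oxygen on a saturated carbon. For the measured compounds named here, one measured step bears directly on this, the same kind of change, hydroxy to methoxy: a 1.5-fold lower number from compound 2 to compound 3 (0.17 log units; within the scatter). The step from compound 1 to compound 3 concerns configuration only and is also small: a 1.6-fold lower number from compound 1 to compound 3 (0.21 log units; within the scatter). A change of the same sort is therefore expected for compound 4, none beyond the scatter: a 1.2-fold lower number from compound 2 to compound 4 (0.07 log units; within the scatter). Compound 4 is estimated at 30000 nM, within the range 15000 nM to 60000 nM.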

Compound 4, half-maximal inhibitory concentration: 2640 nM
Beside the measured number, compound 4's estimate is 11-fold (1.06 log units) above it; the whole stated range lies above it.
By their numbers in this assay, from the lowest: compound 4; then compounds 3, 2 and 1 (each within the scatter of the next).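

Putting a methyl in place of hydrogen on this oxygen lowers the number sharply, with a 13-fold lower number from compound 2 to compound 4 (1.12 log units; beyond the scatter). The same hydroxy to methoxy change on the oxygen that stays free in compound 4 gives only a 1.5-fold lower number from compound 2 to compound 3 (0.17 log units; within the scatter). So, for these compounds, the outcome depends on which of the two oxygens carries the methyl.

On these data alone, whether a longer chain such as ethyl on this oxygen, or an amine in its place, would give a similar number remains open. Nothing shown here explains why the two oxygens differ.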